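Replacing 3-Methylphenyl with 4-Fluorophenyl in Compound 3

This account rests on a few compounds, and the source may have more. Where it says the series, first, only, none or still open, it means among the compounds named here.

Compound 3 `CCC(C(=O)N1CCN(c2cccc(C)c2)CC1)N1C(=O)CCC1=O` is measured in a functional assay on the whole organism (strain Swiss) with Mus musculus as the target, in the maximal electroshock model, with a stated time of 0.25 h, at a dose of 300 mg/kg by the intraperitoneal route (a lower number here means a weaker effect, a higher number a stronger effect of the compound at the dose given), at 100%. That number is level with compound 2 `CC(C(=O)N1CCN(c2ccc(F)cc2)CC1)N1C(=O)CCC1=O`, which gives 100% in the same test, the two standing together at the top of the three compounds, and it lies above compound 1 `CCC(C(=O)N1CCN(c2ccccc2)CC1)N1C(=O)CCC1=O`, which gives 75%. Within the data shown here, only one step between neighbours is known: a number 25 percentage points higher from compound 1 to compound 3 (beyond the scatter). Compound 4 `CCC(C(=O)N1CCN(c2ccc(F)cc2)CC1)N1C(=O)CCC1=O` differs from compound 3 in one place: 4-fluorophenyl in place of 3-methylphenyl on an amine nitrogen in a ring. Among the measured compounds shown here, no measured step shows this exchange by itself. Compound 2 carries the same 4-fluorophenyl group as compound 4 but differs from it in a second place, so its value can only be set side by side with that of compound 3, and the two values agree within the scatter. The step from compound 1 to compound 3 concerns the methyl alone and does not bear on the fluorine. Compound 4 is therefore expected to show no change beyond the scatter, no change at the digits printed from compound 3 to compound 4 (within the scatter), with an estimated 100% in the range 85% to 100%.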

Compound 4, a percentage reported as activity, at one dose (the size of the read-out at that dose, not a potency): 0%
The estimate for compound 4 lay 100 percentage points above the measured number; the whole stated range lies above it.
By their numbers in this assay, from the lowest: compound 4; then compound 1; then compounds 2 and 3 (each within the scatter of the next).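

In this assay, the aromatic group on the amine nitrogen in a ring now proves decisive: exchanging 3-methylphenyl for 4-fluorophenyl gives a number 100 percentage points lower from compound 3 to compound 4 (beyond the scatter), and adding the fluoro group alone to the aromatic ring gives a number 75 percentage points lower from compound 1 to compound 4 (beyond the scatter), whereas the methyl exchange had raised the number. The effect of the 4-fluorophenyl group also depends on the chain, since methyl in place of hydrogen on a saturated chain carbon gives a number 100 percentage points lower from compound 2 to compound 4 (beyond the scatter), so the two places cannot be read independently. No available evidence accounts for this loss.

As far as these compounds go, it remains open whether a chloro or methoxy group on the aromatic ring would behave like the methyl or like the fluoro. From the compounds shown here alone, a longer chain in the same place on the shared core also remains untested against either aromatic group.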